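The source may hold more compounds than are shown below. What is called first, only, known or untested is meant among the compounds shown, and "the series" means these compounds.

Measured compounds in a functional assay on LNCaP C4-2 cells (Homo sapiens) for cytotoxicity, read by MTT assay, with a stated time of 48 h, in the presence of a further agent that is not named here; a lower number here means a stronger inhibitor, a higher number a weaker inhibitor:

Compound 1 `COc1ccc2[nH]cc(-c3nc(C(=O)Nc4cc(OC)c(OC)c(OC)c4)cs3)c2c1` gives > 100000 nM, a limit of the assay and not a number.
Compound 2 `O=C(Nc1ccccc1)c1csc(-c2cn(Cc3ccc(Cl)cc3)c3ccccc23)n1` gives > 100000 nM, again only a limit.
Compound 3 `COc1cc(NC(=O)c2csc(-c3cn(Cc4ccc(Cl)cc4)c4ccccc34)n2)cc(OC)c1OC` gives > 100000 nM, likewise a limit.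

Compound 3 thus stands at the limit of this assay, as do both other measured compounds; no numerical potency is known for any of them. For the measured compounds named here, the one single-point step recorded, a step that the two limits leave unreadable from compound 2 to compound 3, runs between two limits and its size cannot be read. Going by the values given here, the only evidence on the set is the limit of > 100000 nM in this assay, at which 3 of the 3 values shown sit, a limit at which every value shown sits.

Compound 4 `COc1ccc(NC(=O)c2csc(-c3cn(Cc4ccc(Cl)cc4)c4ccccc34)n2)cc1` is the next compound. 4-methoxyphenyl in place of 3,4,5-trimethoxyphenyl on an amide-type nitrogen

The step from compound 2 to compound 3 is the only one touching the amide-type nitrogen substituent, and it is unreadable, so no size or direction can be taken from it. With all three measured values at the limit, the expectation for compound 4 is a further limit rather than a measured number, and the step of a number no higher from compound 3 to compound 4 (the limit leaves the size open) is estimated as none beyond the scatter. Compound 4 is therefore estimated at 100000 nM, with a range from 30000 nM to 300000 nM, most likely reported again as a limit.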

Compound 4, half-maximal inhibitory concentration: > 100000 nM
Compound 4 gave a limit, no number; the forecaster's own chance of this, stated with the estimate: 85%; the middle value sits exactly at the limit.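

Compound 4 gives > 100000 nM, a limit and not a number. The steps from compound 2 and compound 3 to compound 4 run between limits and cannot be read. The compounds shown leave open what structural change, if any, would give a numerical potency in this assay.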